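The source may hold more compounds than are shown below. What is called first, only, known or untested is meant among the compounds shown, and "the series" means these compounds.

Measured so far:
- compound 1, `COc1ccc(CN2CCc3nc(-c4ccccn4)nc(N4CCN(CCN(C)C)CC4)c3C2)cc1`: "not active" (no number reported) in an assay on A549 cells with Cystic fibrosis transmembrane conductance regulator variant F508del (Homo sapiens) as the target, read by fluorescence, with a stated time of 25 min; a higher number here means a larger maximal response, a lower number a smaller maximal response
- compound 2, `COc1ccc(CN2CCc3nc(-c4ccccn4)nc(N4CCN(CC(N)=O)CC4)c3C2)cc1`: 36.8% in this assay

Compound 1 is recorded in this assay as "not active" (no number reported), so no single number stands for it and its place in the series cannot be fixed on the scale. Compound 2 gives 36.8% in this assay. Going by the values given here, the two share the core and differ in one group attached to it; no step between them has been worked out, and their two values show only that compound 2 reaches a measured largest response where compound 1 is reported as not active.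

Compound 3 `CN(C)CCN1CCN(c2nc(-c3ccccn3)nc3c2CN(CC2CCCCC2)CC3)CC1` is not yet measured. It differs from compound 1 by cyclohexyl in place of 4-methoxyphenyl on a saturated chain carbon bound to an amine nitrogen in a ring; the rest of compound 1 is kept unchanged. Among the compounds with values here, no step between measured compounds is available to size this change. Given that compound 1 reads "not active" (no number reported), the expected outcome for compound 3 is at most a small largest response, and a rise beyond the usual scatter is not expected. For compound 3 the largest response in this assay is estimated at 12%, within a range from 0% to 35%, and a report of not active is likely.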

Compound 3, largest response reached (Emax), in percent of the reference or control that the assay uses: "not active" (no number reported)
Compound 3: no number reported; the estimate stays without a comparison.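

In this assay compound 3 reads "not active" (no number reported) and compound 1 reads "not active" (no number reported), so no new step can be read for 4-methoxybenzyl to cyclohexylmethyl. The compounds shown leave open whether this exchange changes the largest response in a compound that gives a measurable one. No measured evidence bears on this result.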